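The source may report more compounds than this note shows. Statements on the series, on what has been measured and on what is new or still open speak of the compounds shown alone.

Measured so far in a functional assay (aorta) with Oryctolagus cuniculus as the target; a lower number here means tighter binding, a higher number weaker binding:
- compound 1 `Fc1ccc(C(c2ccc(F)cc2)C2CCN(CCCOc3ccc(Br)cc3)CC2)cc1`: 1.59 nM
- compound 2 `Fc1ccc(C(c2ccc(F)cc2)C2CCN(CCCCc3ccccc3)CC2)cc1`: 2.51 nM

Going by the values given here, compound 2 lies within the scatter of compound 1, the only other compound measured, so the two cannot be ranked. Compound 3 `Fc1ccc(C(c2ccc(F)cc2)C2CCN(CCCSc3ccccc3)CC2)cc1` keeps the core and chain of compound 2 but carries phenylsulfanyl in place of benzyl on a saturated chain carbon, three bonds along the chain from an amine nitrogen in a ring. Among the compounds with values here, one measured step bears on this place, a 1.6-fold higher number from compound 1 to compound 2 (0.20 log units; within the scatter), and it stays within the scatter. Within the data shown here, no measured compound carries phenylsulfanyl, so this single step is thin support. No step beyond the scatter is therefore expected in this assay. The expected step is a 1.3-fold lower number from compound 2 to compound 3 (0.10 log units; within the scatter). For compound 3 the estimated value is 2 nM, with an expected range from 0.8 nM to 5.5 nM.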

Compound 3, dissociation constant: 3.16 nM
Beside the measured number, compound 3's estimate is 1.6-fold (0.20 log units) below it, and the stated range covers the measured number.
By their numbers in this assay, from the lowest: compounds 1, 2 and 3 (each within the scatter of the next).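

At this place, on a saturated chain carbon, three bonds along the chain from an amine nitrogen in a ring, phenylsulfanyl in place of benzyl gives a 1.3-fold higher number from compound 2 to compound 3 (0.10 log units; within the scatter) in this assay, and phenylsulfanyl in place of 4-bromophenoxy gives a 2.0-fold higher number from compound 1 to compound 3 (0.30 log units; within the scatter). Going by these compounds alone, with these two steps added to the earlier one, three different groups at this place, attached through carbon, oxygen or sulfur, cannot be ranked, and no step among them lies beyond the scatter. Nothing measured here offers an explanation for these numbers.

The compounds shown leave open whether any group at this place can move the number beyond the scatter, such as an amine or a carboxylic acid at the end of the chain. They also leave open what a longer chain would do.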